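Ring-nitrogen substituent of compound 2 replaced by hydroxy

This account rests on a few compounds, and the source may have more. Where it says the series, first, only, none or still open, it means among the compounds named here.

Compound 2 `O=C(NC1COCC(=O)N(Cc2ccco2)C1=O)OCc1ccccc1` stands only at a limit in a functional assay on the whole organism (strain ICR) with Mus musculus as the target, in the maximal electroshock model, with a stated time of 30 min; on this read-out lower numbers stand for an effect already at smaller amounts and higher numbers for an effect only at larger amounts of compound: compound 2 gives > 100 mg/kg, a limit of the assay and not a number. Compound 1 `O=C(NC1COCC(=O)N(Cc2ccc(F)cc2)C1=O)OCc1ccccc1` gives > 100 mg/kg in this assay, again a limit. The step that the two limits leave unreadable from compound 1 to compound 2 stays unreadable, as the limit of > 100 mg/kg in this assay, at which 2 of the 2 values shown sit, shows. Compound 3 `O=C(NC1COCC(=O)N(O)C1=O)OCc1ccccc1` differs by hydroxy in place of (furan-2-yl)methyl on an amide-type nitrogen in a ring. Among the compounds with values here, no measured step bears on this change, so no direction beyond the scatter is expected in this assay. Compound 3 is expected at 150 mg/kg, with a range from 50 mg/kg to 500 mg/kg, most probably again as a limit. The expected step is a step that the limit leaves unreadable from compound 2 to compound 3.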

Compound 3, dose for half-maximal effect: 93.8 mg/kg
Compound 3: middle estimate off by 1.6-fold (0.20 log units), on the high side; the range from low to high includes it.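

In this assay, compound 3 is the only one of the three compounds shown with a number rather than a limit, so hydroxy on the amide-type nitrogen in a ring still gives a readable effect without either larger group. Hydroxy gives an at least 1.0-fold lower number from compound 2 to compound 3 (0.02 log units; that floor lies within the scatter), and it gives an at least 1.0-fold lower number from compound 1 to compound 3 (0.02 log units; that floor lies within the scatter), so no gain over either group can be claimed. These floors rest on limits, and the step between the two earlier compounds still cannot be read: the limit of > 100 mg/kg in this assay, at which 2 of the 3 values shown sit.

As far as these compounds go, the true size of both steps remains open. From the compounds shown here alone, it is also open how methoxy or an aminoethyl chain on this nitrogen would read in this assay.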